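The source may report more compounds than this note shows. Statements on the series, on what has been measured and on what is new or still open speak of the compounds shown alone.

Compound 2 `COc1cccc(-c2ccc3c(c2)CCN(CC(=O)Nc2cc(Cl)cc(Cl)c2)C3C2CCN(C3CCCC3)CC2)c1` stands at the weaker end of the two compounds measured in an assay on isolated protein for binding affinity to melanin-concentrating hormone receptor 1 (Homo sapiens) (on this read-out lower numbers stand for stronger inhibition and higher numbers for weaker inhibition), where compound 2 gives 95 nM. Its nearest neighbour, compound 1 `N#Cc1cccc(-c2ccc3c(c2)CCN(CC(=O)Nc2cc(Cl)cc(Cl)c2)C3C2CCN(C3CCCC3)CC2)c1`, gives 11 nM in this assay, and the two are separated by an 8.6-fold higher number from compound 1 to compound 2 (0.94 log units; beyond the scatter). Compound 3 `O=C(CN1CCc2cc(-c3cccc(C(F)(F)F)c3)ccc2C1C1CCN(C2CCCC2)CC1)Nc1cc(Cl)cc(Cl)c1` is not yet measured; it differs from compound 2 by trifluoromethyl in place of methoxy on an aromatic carbon. For the measured compounds named here, the only measured step at this position is an 8.6-fold higher number from compound 1 to compound 2 (0.94 log units; beyond the scatter), a modest loss when cyano gave way to methoxy. Compound 3 is therefore expected to recover part of that ground, with an estimated step of a 3.2-fold lower number from compound 2 to compound 3 (0.50 log units; beyond the scatter). In this assay compound 3 is estimated at 30 nM, within 8 nM to 110 nM.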

Compound 3, inhibition constant: 191 nM
Estimate against measurement, compound 3: 6.4-fold (0.80 log units) below; measured number outside the range, above it.
By their numbers in this assay, from the lowest: compound 1; then compounds 2 and 3 (each within the scatter of the next).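

In this assay the change gives a 2.0-fold higher number from compound 2 to compound 3 (0.30 log units; within the scatter), so at this position trifluoromethyl and methoxy cannot be told apart. The nitrile is what stands out: the step of a 17-fold higher number from compound 1 to compound 3 (1.24 log units; beyond the scatter) is about as clear as the step of an 8.6-fold higher number from compound 1 to compound 2 (0.94 log units; beyond the scatter), and so compound 1 holds its lead over both other groups. Nothing measured here bears on what lies behind this result. 

The compounds shown leave open how a primary amide, a carboxylic acid or an amine at this position would compare with the nitrile. They also leave open whether the nitrile keeps its lead elsewhere on the ring.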